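A few compounds are considered here, and "the series" means these few. Any claim that something is new, unique, unknown or untested is made for them only; others in the source may bear on it.

Of the compounds shown here, three that share one core have been tested in a functional assay on MT4 cells (Homo sapiens) for cytotoxicity, read by MTT assay (on this read-out lower numbers stand for higher toxicity in this test and higher numbers for lower toxicity in this test), and they differ only in a single group on an aromatic carbon. Compound 1 `Cc1c(O)nc(SCc2ccc(O)cc2)nc1Cc1c(Cl)cccc1Cl`, which carries hydroxy, gives 41000 nM. Compound 2 `Cc1c(O)nc(SCc2ccc([N+](=O)[O-])cc2)nc1Cc1c(Cl)cccc1Cl`, which carries nitro, gives > 58000 nM, and this is a limit of the assay and not a number. Compound 3 `Cc1c(O)nc(SCc2ccc(F)cc2)nc1Cc1c(Cl)cccc1Cl`, which carries fluoro, gives > 61000 nM, and this too is only a limit. Compound 3 therefore has no exact place on the scale.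

Compound 4 `Cc1c(O)nc(SCc2ccc(Br)cc2)nc1Cc1c(Cl)cccc1Cl` has not yet been measured. It differs from compound 3 by one swap, bromo in place of fluoro on an aromatic carbon, para to a large group.

Among the measured compounds shown here, no measured step involves bromo, so the closest guide is what other swaps of this group have done. One is an at least 1.4-fold higher number from compound 1 to compound 2 (0.15 log units; that floor lies within the scatter), and another is an at least 1.4-fold higher number from compound 1 to compound 3 (0.17 log units; that floor lies within the scatter). The third comparison is a step that the two limits leave unreadable from compound 2 to compound 3. None of these shows a change beyond the scatter, so no step beyond the scatter is expected in this assay, in either direction, and another limit is quite possible. The expected size is an at least 1.3-fold lower number from compound 3 to compound 4 (0.13 log units; that floor lies within the scatter). The estimated value for compound 4 is 45000 nM, with an expected range from 18000 nM to 70000 nM.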

Compound 4, half-maximal cytotoxic concentration: 13000 nM
For compound 4 the middle estimate is 3.5-fold (0.54 log units) above the measured one; measured number outside the range, below it.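

In this assay, among the compounds shown here, the group at this place on the benzyl ring can change the result, something the earlier compounds could not show: going to the 4-bromobenzyl form gives an at least 4.6-fold lower number from compound 3 to compound 4 (0.67 log units; beyond the scatter) and an at least 4.4-fold lower number from compound 2 to compound 4 (0.64 log units; beyond the scatter). For the compounds shown here, both of these steps start from a limit and so give only a floor, while the only step with an exact value at both ends is a 3.2-fold lower number from compound 1 to compound 4 (0.50 log units; beyond the scatter). Compound 4 thus gives the first change at this position that clearly exceeds the scatter, pointing toward higher toxicity in this test, but nothing shown here explains why bromo behaves this way.

On these data alone, it remains open whether chloro or iodo at the same place would behave like bromo or like fluoro, and whether a methyl or an amine there would give a number closer to that of compound 4 or compound 1. Also unknown is how far the true numbers of compound 2 and compound 3 lie past their limits, which leaves the full size of the steps to compound 4 unsettled.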